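This account rests on a few compounds, and the source may have more. Where it says the series, first, only, none or still open, it means among the compounds named here.

Three compounds built on the same tetrabrominated diaryl ether core have been tested in a functional assay on U-937 cells (Homo sapiens) for cytotoxicity, read by MTT assay, with a stated time of 24 h; a higher number here means a weaker inhibitor, a lower number a stronger inhibitor. Compound 1, `Brc1ccc(Oc2cc(Br)cc(Br)c2OCCCCCN2CCN(c3ccccc3)CC2)c(Br)c1`, carries a long chain ending in a phenyl-substituted piperazine and gives 42.5 ug/mL. Compound 3, `Cc1ccc(S(=O)(=O)n2nc(N3CCN(CCCCCOc4c(Br)cc(Br)cc4Oc4ccc(Br)cc4Br)CC3)c3cc([N+](=O)[O-])ccc32)cc1`, carries a far larger group at the end of its chain and gives 68.5 ug/mL. Compound 2, `OCCCOc1c(Br)cc(Br)cc1Oc1ccc(Br)cc1Br`, carries only a short hydroxy-bearing chain on the core and gives 32.3 ug/mL. The number for compound 2 and the number for compound 1 sit within the scatter of each other, so no order can be read between them; the number for compound 3 stands beyond the scatter above that of compound 2.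

Compound 4, `C#CCOc1c(Br)cc(Br)cc1Oc1ccc(Br)cc1Br`, has not yet been measured. It differs from compound 2 in one place: ethynyl in place of 2-hydroxyethyl on a saturated chain carbon bound to an oxygen on an aromatic ring. Within the data shown here, no measured pair here shows a change of this kind, so nothing in the data says which way such a step goes. The step from compound 2 to compound 4 is therefore expected to stay within the scatter, a 1.1-fold lower number from compound 2 to compound 4 (0.03 log units; within the scatter). Compound 4 is expected to give 30 ug/mL, with a range from 15 ug/mL to 60 ug/mL.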

Compound 4, half-maximal inhibitory concentration: 29.5 ug/mL
Compound 4: the middle estimate sits 1.0-fold (0.01 log units) above what was measured; the measured number falls inside the stated range.
By their numbers in this assay, from the lowest: compounds 4, 2, 1 and 3 (each within the scatter of the next, the first and the last beyond it).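

Among these compounds, this is the first pair in the set that differs in one place. In this assay, replacing 2-hydroxyethyl with ethynyl on a saturated chain carbon bound to an oxygen on an aromatic ring gives a 1.1-fold lower number from compound 2 to compound 4 (0.04 log units; within the scatter), so no change can be read from this swap, even though the group that enters has no hydrogen-bond donor or acceptor and the group that leaves has one of each. Nothing measured here offers an explanation for why these two compounds read alike.

A single pair cannot show whether other groups at this chain end, such as a carboxylic acid or an amide, would also leave the number unchanged. It also leaves open whether the same swap would read alike on a longer chain.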